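Methyl on the chain of a cinnamylidene hydrazone series

A few compounds are considered here, and "the series" means these few. Any claim that something is new, unique, unknown or untested is made for them only; others in the source may bear on it.

Compound 1 `CCN1C(=O)N(CC)C2C1NC(=S)N2/N=C/C=C/c1ccccc1` is the parent of the set. In a functional assay on MCF7 cells (Homo sapiens) for inhibition, read by MTT assay, with a stated time of 72 h (on this read-out lower numbers stand for stronger inhibition and higher numbers for weaker inhibition), compound 1 gives 36100 nM. The two aryl-substituted analogues sit within the scatter of it: compound 2 `CCN1C(=O)N(CC)C2C1NC(=S)N2/N=C/C=C/c1ccccc1[N+](=O)[O-]` gives 43900 nM in this assay, and compound 3 `CCN1C(=O)N(CC)C2C1NC(=S)N2/N=C/C=C/c1ccc(OC)cc1` gives 36600 nM. The steps of a 1.2-fold higher number from compound 1 to compound 2 (0.08 log units; within the scatter) and a 1.0-fold higher number from compound 1 to compound 3 (0.01 log units; within the scatter) show that neither the nitro nor the methoxy moves the number beyond the scatter, and the step of a 1.2-fold lower number from compound 2 to compound 3 (0.08 log units; within the scatter) between the two substituted analogues is likewise flat.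

Compound 4 `CCN1C(=O)N(CC)C2C1NC(=S)N2/N=C/C(C)=C/c1ccccc1` differs from compound 1 by methyl in place of hydrogen on a double-bonded chain carbon bound to a carbon with a double bond to nitrogen and a double-bonded chain carbon. Within the data shown here, none of the measured steps touches the chain; all three change only the aryl ring, so there is no direct precedent for a substituent on the chain carbon. What the three numbers do show is a series that so far has not responded to any change beyond the scatter, which gives no ground to expect a shift in this assay in either direction for compound 4. The step from compound 1 to compound 4 is therefore expected to be a 1.1-fold higher number from compound 1 to compound 4 (0.02 log units; within the scatter), within the scatter. Compound 4 is estimated at 38000 nM in this assay, with a range from 18000 nM to 80000 nM.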

Compound 4, half-maximal inhibitory concentration: 35100 nM
For compound 4 the middle estimate is 1.1-fold (0.03 log units) above the measured one; measured number inside the range.
By their numbers in this assay, from the lowest: compounds 4, 1, 3 and 2 (each within the scatter of the next).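

In this assay the chain now has a measured step of its own: the change gives a 1.0-fold lower number from compound 1 to compound 4 (0.01 log units; within the scatter) and so stays level with the parent. The earlier steps changed only the aryl ring, whereas this one shows that methyl in place of hydrogen on a double-bonded chain carbon bound to a carbon with a double bond to nitrogen and a double-bonded chain carbon is also accepted without a shift beyond the scatter, so the flat picture from compound 1, compound 2 and compound 3 now holds for compound 4 as well, and no compound shown goes against it. Nothing measured here bears on why the number stays level at this position.

Open, on these data alone, is whether a longer chain such as ethyl, or a phenyl, on the same chain carbon would leave the number equally flat, and whether an amine or a carboxylic acid on the aryl ring would move it beyond the scatter. Also open, as far as these compounds go, is whether the methyl on the chain, taken together with the nitro or the methoxy on the aryl ring, would still stay level with the parent.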